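Removing the fluoro group from compound 3

The source may hold more compounds than are shown below. What is called first, only, known or untested is meant among the compounds shown, and "the series" means these compounds.

In a toxicity assay on MT2 cells (Homo sapiens) for cytotoxicity, read by XTT assay, with a stated time of 4 days (a lower number here means that less compound is tolerated, a higher number that more compound is tolerated), compound 1 (`Cc1nc([C@H](NC(=O)c2ccc(-c3ccc(Cl)cc3)[nH]2)[C@@H]2CCCCN2)sc1CCO`) gives 21000 nM, compound 2 (`Cc1ccc(-c2ccc(C(=O)N[C@@H](c3nc(C)c(CCCO)s3)[C@@H]3CCCCN3)[nH]2)cc1F`) gives 20600 nM and compound 3 (`Cc1nc([C@H](NC(=O)c2ccc(-c3ccc(Cl)c(F)c3)[nH]2)[C@@H]2CCCCN2)sc1CCCO`) gives 12600 nM. Compound 3 lies within the scatter of both other compounds, so these three numbers support no ranking.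

The unmeasured compound 4 (`Cc1nc([C@H](NC(=O)c2ccc(-c3ccc(Cl)cc3)[nH]2)[C@@H]2CCCCN2)sc1CCCO`) differs from compound 3 by hydrogen in place of fluoro on an aromatic carbon. This places hydrogen in place of fluoro on an aromatic carbon, turning 4-chloro-3-fluorophenyl into 4-chlorophenyl. Within the data shown here, no measured step makes this exchange, so the evidence is indirect. Among the measured compounds shown here, the only measured step, a 1.6-fold lower number from compound 2 to compound 3 (0.21 log units; within the scatter), is a change of chloro in place of methyl on an aromatic carbon of the same six-membered aromatic ring, and it stays within the scatter. Going by these compounds, with that step so small and all three measured numbers within the scatter of one another, nothing here points to a move beyond the scatter, and the direction remains open.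

The estimated change is a 1.3-fold higher number from compound 3 to compound 4 (0.10 log units; within the scatter), which is expected to remain within the scatter. Compound 4 is expected at 16000 nM, with an estimated range of 9000 nM to 28000 nM.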

Compound 4, half-maximal cytotoxic concentration: 19000 nM
Beside the measured number, compound 4's estimate is 1.2-fold (0.07 log units) below it, and the stated range covers the measured number.
By their numbers in this assay, from the lowest: compounds 3, 4, 2 and 1 (each within the scatter of the next).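

In this assay, the exchange of fluoro for hydrogen on the aromatic carbon ortho to the chloro group now has a direct reading, which gives a 1.5-fold higher number from compound 3 to compound 4 (0.18 log units; within the scatter) and does not separate 4-chloro-3-fluorophenyl from 4-chlorophenyl at this position. Compound 4 also adds two other single-place comparisons: 4-chlorophenyl in place of 3-fluoro-4-methylphenyl gives a 1.1-fold lower number from compound 2 to compound 4 (0.04 log units; within the scatter) and hydroxymethyl in place of hydroxy on the saturated chain gives a 1.1-fold lower number from compound 1 to compound 4 (0.04 log units; within the scatter) so all three exchanges stay inside the scatter in this cytotoxicity read-out. No measurement shown bears on why these exchanges leave the number where it is.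

Still open, going by these compounds, is whether a different group on this aromatic carbon, such as methoxy, nitrile or trifluoromethyl, would take the number beyond the scatter. The same question stands for an amine, a carboxylic acid or a longer chain in place of the terminal hydroxy-bearing chain, and the shared core stays constant across all four compounds, so these numbers say nothing about changes there.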